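Benzylsulfanyl for butoxy: cytotoxicity outlook for compound 4

The source may report more compounds than this note shows. Statements on the series, on what has been measured and on what is new or still open speak of the compounds shown alone.

Compound 3 `CCCCOc1nc(N)nc2c1ncn2/C=C1/CC1(CO)CO` carries a butoxy group on the shared core. In an ADME assay on BCBL1 cells (Homo sapiens) for cytotoxicity, with a stated time of 7 days (a higher number here means that more compound is tolerated, a lower number that less compound is tolerated), compound 3 gives > 20000 nM, which is a limit of the assay and not a number. Compound 1 `CCCCCCCCOc1nc(N)nc2c1ncn2/C=C1/CC1(CO)CO`, the octyloxy analogue, likewise reaches only a limit in this assay, giving > 20000 nM. Compound 2 `Nc1nc(OCC(F)(F)F)c2ncn(/C=C3/CC3(CO)CO)c2n1` also stops at a limit in this assay, giving > 20000 nM. Among the measured compounds shown here, the overall picture is the limit of > 20000 nM in this assay, at which 3 of the 3 values shown sit: compound 3 stands at the same limit as compound 1 and compound 2, and no measured compound shows a readable toxicity within the tested range.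

The measured steps are a step that the two limits leave unreadable from compound 1 to compound 3, a step that the two limits leave unreadable from compound 1 to compound 2 and a step that the two limits leave unreadable from compound 2 to compound 3; all three are of a size the limits leave unreadable, so they set no scale for any change of the alkoxy chain.

Compound 4 `Nc1nc(SCc2ccccc2)c2ncn(/C=C3/CC3(CO)CO)c2n1` differs from compound 3 in this way: benzylsulfanyl in place of butoxy on an aromatic carbon. For the measured compounds named here, no measured step covers a benzylsulfanyl group or a sulfur-linked substituent, and the steps among compound 1, compound 2 and compound 3 offer no readable size. The expected step of a number no higher from compound 3 to compound 4 (the limit leaves the size open) is therefore none beyond the scatter, with a further limit the most probable report. Compound 4 is estimated at 20000 nM, in the range 5000 nM to 60000 nM.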

Compound 4, half-maximal cytotoxic concentration: > 20000 nM
Compound 4 ended at the assay's limit; the forecaster's own chance of this, stated with the estimate: 70%; the middle value sits exactly at the limit.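

In this assay compound 4 gives > 20000 nM, a limit of the assay and not a number, so its steps from compound 1, compound 2 and compound 3 cannot be read. The compounds shown leave open what concentration of any of them would be cytotoxic in this assay, and whether benzylsulfanyl differs from the alkoxy groups there.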